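Shortening the Chain on a Shared Core

The compounds below may be only part of what the source reports. "The series", "measured", "known", "first", "only" and "open" are said of these compounds alone.

Two compounds with the same core carry different chains on an oxygen attached to an aromatic ring. Compound 1 `CC(C)COc1ccc2c(Cl)ccnc2c1` bears a branched short chain, and compound 2 `CCCCCCCCOc1ccc2c(Cl)ccnc2c1` a long straight one. In a functional assay on BGC-823 cells (Homo sapiens) for cytotoxicity, read by MTT assay, with a stated time of 48 h (on this read-out higher numbers stand for weaker inhibition and lower numbers for stronger inhibition), compound 1 gives 3030 nM, while compound 2 gives 4300 nM. Compound 2 thus stands at the higher of the two numbers, but the gap to compound 1 lies within the usual scatter of repeated measurements, so the two cannot be told apart on these data.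

Compound 3 `CCCCCCOc1ccc2c(Cl)ccnc2c1` is the next case: hydrogen in place of ethyl on a saturated chain carbon, six bonds along the chain from an oxygen on an aromatic ring. Going by the values given here, no pair among the measured compounds differs in exactly one place, so there is no measured step to lean on. What the two values do show is that a short branched chain and a long straight chain give numbers that sit together within the scatter. Among the compounds with values here, a chain of middle length is therefore expected to land near the same level, with no step from compound 2 to compound 3 beyond the scatter; the step is estimated at a 1.2-fold lower number from compound 2 to compound 3 (0.09 log units; within the scatter). Compound 3 is expected to give about 3500 nM in this assay, in a range from 1800 nM to 7000 nM.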

Compound 3, half-maximal inhibitory concentration: 2380 nM
Compound 3: the middle estimate sits 1.5-fold (0.17 log units) above what was measured; the measured number falls inside the stated range.
By their numbers in this assay, from the lowest: compounds 3, 1 and 2 (each within the scatter of the next).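

Going by these compounds alone, compound 3 supplies the first steps that can be read at this position, and both stay small. In this assay, hydrogen in place of ethyl on a saturated chain carbon, six bonds along the chain from an oxygen on an aromatic ring, gives a 1.8-fold lower number from compound 2 to compound 3 (0.26 log units; within the scatter) and so does not separate the two compounds. Pentyl in place of isopropyl on a saturated chain carbon bound to an oxygen on an aromatic ring gives a 1.3-fold lower number from compound 1 to compound 3 (0.10 log units; within the scatter), so this straight chain and this branched chain also read alike here, and no evidence is available to account for these results.

All three compounds share the same core and differ only in the carbon chain on the oxygen, so these steps say nothing about changes made anywhere else on the core. As far as these compounds go, it remains open whether an amine or a carboxylic acid at the end of the chain, a phenyl ring in its place, or a chain longer than that of compound 2 would produce a step beyond the scatter.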